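Swapping the Aryl Ester for a Methoxyphenoxy Ether

The source may hold more compounds than are shown below. What is called first, only, known or untested is meant among the compounds shown, and "the series" means these compounds.

In an assay on isolated protein for agonist activity at Bile acid receptor (Homo sapiens), read by AlphaScreen, with a stated time of 30 min (a lower number here means that less compound is needed, a higher number that more compound is needed for the effect), compound 2 `COC(=O)c1cccc(-c2ccc([C@H]3S[C@@H](C)C(=O)Nc4c3c(C)nn4-c3ccccc3C)cc2)c1` was recorded as "not active" (no number reported), so no single number stands for it. Two relatives carry a phenoxy group at the same place: compound 1 `CCCc1ccccc1-n1nc(C)c2c1NC(=O)[C@H](C)S[C@@H]2c1ccc(Oc2ccccc2)cc1` gives 1100 nM in this assay, and compound 3 `Cc1nn(-c2ccccc2Br)c2c1C(c1ccc(Oc3ccccc3)cc1)SC(C)C(=O)N2` gives 1800 nM. Compound 4 `COc1ccccc1Oc1ccc([C@H]2S[C@@H](C)C(=O)Nc3c2c(C)nn3-c2ccccc2C)cc1` differs from compound 2 by 2-methoxyphenoxy in place of 3-(methoxycarbonyl)phenyl on an aromatic carbon. Within the data shown here, no measured step describes this change, so the direction is judged from the phenoxy relatives: a move from no activity toward a measurable concentration is expected, well beyond the scatter, though the step cannot be sized. Compound 4 is therefore expected near 1500 nM, plausibly between 400 nM and 6000 nM.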

Compound 4, half-maximal effective concentration: 1700 nM
Compound 4: middle estimate off by 1.1-fold (0.05 log units), on the low side, within the range that was stated.
By their numbers in this assay, from the lowest: compounds 1, 4 and 3 (each within the scatter of the next).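

Compound 2 has no number, so no step from it to compound 4 can be read, and nothing measured here offers an explanation. The compounds shown leave open how much 2-methoxyphenoxy itself contributes in this assay on this core.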